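The source may hold more compounds than are shown below. What is called first, only, known or untested is meant among the compounds shown, and "the series" means these compounds.

Measured compounds in a functional assay on HCT-116 cells (Homo sapiens) for antiproliferative activity, read by MTT assay, with a stated time of 48 h; on this read-out lower numbers stand for stronger inhibition and higher numbers for weaker inhibition:

- compound 1 `COc1cc(-c2nnc(SCC(=O)c3ccc(F)cc3)n2N)cc(OC)c1OC`, 3230 nM
- compound 2 `COc1cc(-c2nnc(SCC(=O)c3cccc(Br)c3)n2N)cc(OC)c1OC`, 5320 nM
- compound 3 `COc1ccc(C(=O)CSc2nnc(-c3cc(OC)c(OC)c(OC)c3)n2N)cc1`, 1240 nM

Among these three, compound 1 stands second highest. Its nearest neighbour is compound 2, with a 1.6-fold higher number from compound 1 to compound 2 (0.22 log units; within the scatter), a step that stays within the scatter; its furthest is compound 3, with a 2.6-fold lower number from compound 1 to compound 3 (0.42 log units; beyond the scatter), a step beyond the scatter. Between the other two, a 4.3-fold lower number from compound 2 to compound 3 (0.63 log units; beyond the scatter).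

Compound 4 `COc1cc(-c2nnc(SCC(=O)Nc3ccccc3C)n2N)cc(OC)c1OC` is not yet measured. It differs from compound 1 by (2-methylphenyl)amino in place of 4-fluorophenyl on a carbonyl carbon. Going by the values given here, no measured step bears directly on this change: all three steps swap one aryl group for another on the carbonyl carbon, and the largest of them, a 4.3-fold lower number from compound 2 to compound 3 (0.63 log units; beyond the scatter), is modest. Among the compounds with values here, the change to compound 4 alters the carbonyl neighbour itself, for which the data hold no precedent, so the expectation must be wide. Compound 4 is therefore expected to give roughly 3500 nM in this assay, within 1000 nM to 12000 nM, which means an expected step of a 1.1-fold higher number from compound 1 to compound 4 (0.03 log units; within the scatter), not clearly beyond the scatter in either direction.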

Compound 4, half-maximal inhibitory concentration: > 100000 nM
Compound 4: a limit, no number; the forecaster's own chance of this, stated with the estimate: 10%; middle value at least 28-fold (1.45 log units) away from the limit.
By their numbers in this assay, from the lowest: compound 3; then compounds 1 and 2 (each within the scatter of the next). At a limit, above all of these: compound 4.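

In this assay, compound 4 gives a limit, not a number: the limit of > 100000 nM in this assay, at which 1 of the 4 values shown sits. The earlier swaps of one aryl group for another on the carbonyl carbon produced modest steps at most, whereas (2-methylphenyl)amino in that place produces a large one: an at least 30-fold higher number from compound 1 to compound 4 (1.49 log units; beyond the scatter). The step is also large against the other two aryl groups, with an at least 80-fold higher number from compound 3 to compound 4 (1.90 log units; beyond the scatter) and an at least 18-fold higher number from compound 2 to compound 4 (1.27 log units; beyond the scatter), so in these compounds the change that brings in the amino nitrogen matters far more than any of the aryl swaps.

Compound 4 changes the link to the carbonyl and the ring substituent at once, so the compounds shown cannot say which of the two carries the loss. A (4-fluorophenyl)amino group or a plain 2-methylphenyl on the carbonyl carbon would separate them.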